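The compounds below may be only part of what the source reports. "The series", "measured", "known", "first", "only" and "open" are said of these compounds alone.

Measured so far in a functional assay on RAW264.7 cells (Mus musculus) for inhibition, with a stated time of 30 min; on this read-out lower numbers stand for stronger inhibition and higher numbers for weaker inhibition:
- compound 1, `C=C1C(=O)OC[C@H]1CCOC(=O)Nc1ccc(I)cc1`: 490 nM
- compound 2, `C=C1C(=O)OC[C@@H]1CCOC(=O)Nc1ccc(I)cc1`: 790 nM

Among the compounds with values here, compound 2 gives the highest of the two numbers, and its only neighbour is compound 1, with a 1.6-fold higher number from compound 1 to compound 2 (0.21 log units; within the scatter). Because of the fact that compounds 1 and 2 differ only in the configuration as drawn the two compounds differ only in configuration as drawn, and the step between them lies within the scatter, so the two values cannot be ordered against each other.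

The next compound, compound 3, `C=C1C(=O)OC[C@@H]1CCOC(=O)Nc1ccccc1`, is obtained from compound 2 by hydrogen in place of iodo on an aromatic carbon. Within the data shown here, no measured step concerns this change: the single step seen so far concerns a stereocentre, not the iodo group, and it was small. The measured pair therefore fixes only the scale on which compound 3 should fall, not the direction of the change. Taking away the iodo leaves a smaller aromatic ring, and compound 3 is expected to give a somewhat weaker inhibition, a 2.0-fold higher number from compound 2 to compound 3 (0.31 log units; beyond the scatter), though a result within the scatter of compound 2 would not be surprising. In this assay compound 3 is estimated at 1600 nM, with a range from 500 nM to 5000 nM.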

Compound 3, half-maximal inhibitory concentration: 780 nM
Compound 3: middle estimate off by 2.1-fold (0.31 log units), on the high side, within the range that was stated.
By their numbers in this assay, from the lowest: compounds 1, 3 and 2 (each within the scatter of the next).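

Hydrogen in place of iodo on an aromatic carbon, para to a large group, gives in this assay a 1.0-fold lower number from compound 2 to compound 3 (0.01 log units; within the scatter), so the two compounds cannot be told apart on this read-out. Within the data shown here, this is the first look at this position, and it shows that, for this pair, the iodo group can be replaced by a hydrogen atom, with no heavy atom left at that place, without any change that this assay can resolve; the iodine atom is therefore not needed for the inhibition seen with compound 2. Nothing reported here gives a reason why the exchange leaves the number within the scatter.

What the compounds shown leave open is whether any group at this place can move the number beyond the scatter in either direction, for example a methoxy group, an amine or a carboxylic acid, since iodo and hydrogen are the only two seen there. From the compounds shown here alone, it also remains open whether the same exchange would behave alike on compound 1, which carries the opposite configuration as drawn at the stereocentre.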